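The compounds below may be only part of what the source reports. "The series", "measured", "known", "first", "only" and "open" are said of these compounds alone.

Measured compounds in the series:

Compound 1, `COC(=O)c1c(-c2ccc(OCc3ccccc3)cc2)oc2ccccc2c1=O`. In a functional assay on HT-29 cells (Homo sapiens) for cytotoxicity, read by MTT assay, with a stated time of 6 days (on this read-out higher numbers stand for an effect only at larger amounts of compound and lower numbers for an effect already at smaller amounts), compound 1 gives > 25 ug/mL, which is a limit of the assay and not a number.
Compound 2, `COC(=O)c1c(-c2ccc(OCc3ccccc3)cc2)oc2ccc(OC)cc2c1=O`. In this assay compound 2 gives 15.6 ug/mL.
Compound 3, `O=C(O)c1c(-c2ccc([N+](=O)[O-])cc2)oc2ccccc2c1=O`. In this assay compound 3 gives > 25 ug/mL, again a limit of the assay rather than a number.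

Among the compounds with values here, the one change measured is methoxy in place of hydrogen on an aromatic carbon, which produced an at least 1.6-fold lower number from compound 1 to compound 2 (0.20 log units; that floor lies within the scatter). Since the starting point is a limit, only a floor for that step is known, and the floor itself sits inside the usual scatter; the step may be larger than the floor shows. Two of the three values recorded sit at the limit of > 25 ug/mL in this assay, at which 2 of the 3 values shown sit.

Compound 4, `COc1ccc2c(=O)c(C(=O)O)c(-c3ccc([N+](=O)[O-])cc3)oc2c1`, has not been measured in this assay. It is obtained from compound 3 by methoxy in place of hydrogen on an aromatic carbon, the same change as that from compound 1 to compound 2, with the place described in the same words. The difference between the core of compound 1 and the core of compound 3 is not broken down here.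

The expectation for compound 4 is a step that the limit leaves unreadable from compound 3 to compound 4, taken to be of about the size seen from compound 1 to compound 2, resting on that single measured step, which is itself only a floor from a limit. For compound 4 in this assay the estimate is 28 ug/mL, with a plausible range from 10 ug/mL to 80 ug/mL, and a real chance that the assay again reports only a limit.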

Compound 4, concentration for half-maximal effect: > 25 ug/mL
Compound 4: only a limit was reported; the forecaster's own chance of this, stated with the estimate: 55%; the middle value lies beyond the limit too.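

In this assay compound 4 gives > 25 ug/mL, a limit of the assay and not a number. Compound 3 also stands at a limit, so no step can be read between compound 3 and compound 4: the limit of > 25 ug/mL in this assay, at which 3 of the 4 values shown sit.

The compounds shown leave open whether methoxy in place of hydrogen on an aromatic carbon changes the read-out at all on the core of compound 3.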